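Dimethylamino for pyrrolidin-1-yl on a carbonyl carbon

The source may hold more compounds than are shown below. What is called first, only, known or untested is meant among the compounds shown, and "the series" means these compounds.

In a functional assay on MCF7 cells (Homo sapiens) for antiproliferative activity, read by CCK-8 assay, with a stated time of 48 h (on this read-out higher numbers stand for weaker inhibition and lower numbers for stronger inhibition), compound 1 (`O=C(/C=C/CNCCOc1ccc(Oc2c(-c3ccc(F)cc3)sc3cc(O)ccc23)cc1)N1CCCC1`) gives 7610 nM while compound 2 (`C=CC(=O)NCCOc1ccc(Oc2c(-c3ccc(F)cc3)sc3cc(O)ccc23)cc1`) gives 23000 nM and compound 3 (`O=C(/C=C/CN1CC(Oc2ccc(Oc3c(-c4ccc(F)cc4)sc4cc(O)ccc34)cc2)C1)N1CCCC1`) gives 8450 nM in the same read-out. Compound 3 lies within the scatter of compound 1, and the number for compound 2 is higher than both, beyond the scatter. Compound 4 (`CN(C)C(=O)/C=C/CN1CC(Oc2ccc(Oc3c(-c4ccc(F)cc4)sc4cc(O)ccc34)cc2)C1`) has dimethylamino in place of pyrrolidin-1-yl on a carbonyl carbon of compound 3 (dimethylamino in place of pyrrolidin-1-yl on a carbonyl carbon). Within the data shown here, the only measured step touching this group is a 3.0-fold higher number from compound 1 to compound 2 (0.48 log units; beyond the scatter) (modest), and it replaces the whole 3-((pyrrolidin-1-yl)carbonyl)prop-2-en-1-yl group with vinylcarbonyl. Among the measured compounds shown here, no measured step exchanges pyrrolidin-1-yl alone. The present change is narrower, so the expected step is a 1.1-fold lower number from compound 3 to compound 4 (0.02 log units; within the scatter) and stays within the scatter. Compound 4 is estimated in this assay at 8000 nM (range 3500 nM to 18000 nM).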

Compound 4, half-maximal inhibitory concentration: 22300 nM
Beside the measured number, compound 4's estimate is 2.8-fold (0.45 log units) below it; measured number outside the range, above it.
By their numbers in this assay, from the lowest: compounds 1 and 3 (each within the scatter of the next); then compounds 4 and 2 (each within the scatter of the next).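

Exchanging pyrrolidin-1-yl alone on the carbonyl carbon is not neutral in this assay: dimethylamino gives a 2.6-fold higher number from compound 3 to compound 4 (0.42 log units; beyond the scatter). The ring therefore counts separately from the rest of the 3-((pyrrolidin-1-yl)carbonyl)prop-2-en-1-yl group. Across the much larger exchange on the oxygen on an aromatic ring, the result is a 1.0-fold lower number from compound 2 to compound 4 (0.01 log units; within the scatter), which places this dimethylamino amide with the vinylcarbonyl amide rather than with the pyrrolidine amides.

Nothing available explains the effect of this exchange. From the compounds shown here alone, whether piperidin-1-yl, morpholin-4-yl or methylamino on the carbonyl carbon would track compound 3 or compound 4 remains open.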